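The source may report more compounds than this note shows. Statements on the series, on what has been measured and on what is new or still open speak of the compounds shown alone.

Measured so far:
Compound 1, `Cc1ccccc1N1CCN(CCCCOc2ccc3c(=O)cc(-c4ccccc4)oc3c2)CC1`: 19.5 nM
Compound 2, `Cc1ccccc1N1CCN(CCCCOc2ccc3c(=O)cc(-c4ccc(Cl)cc4)oc3c2)CC1`: 33.8 nM
Compound 3, `O=c1cc(-c2ccccc2)oc2cc(OCCBr)ccc12`: 127 nM

All three were tested in a functional assay for antagonist activity at Adrenergic receptor alpha-1 (Rattus norvegicus); on this read-out higher numbers stand for weaker binding and lower numbers for tighter binding. Compound 1 and compound 2 share one core and differ by a single change, (chloro in place of hydrogen on an aromatic carbon), which gave a 1.7-fold higher number from compound 1 to compound 2 (0.24 log units; within the scatter). Compound 3 has a different core; the difference between the two cores is not broken down here, and its value in this assay is the highest of the three, beyond the scatter from both compound 1 and compound 2.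

Compound 4, `O=c1cc(-c2ccc(Cl)cc2)oc2cc(OCCBr)ccc12`, is not yet measured. It differs from compound 3 by chloro in place of hydrogen on an aromatic carbon, the same change that links compound 1 to compound 2, placed in the same way. Within the data shown here, the only guide to its effect is the single measured step, so the expectation is a step of similar size: a 1.6-fold higher number from compound 3 to compound 4 (0.20 log units; within the scatter), resting on a 1.7-fold higher number from compound 1 to compound 2 (0.24 log units; within the scatter). Because one example is thin evidence, and the core differs, the expected range is kept wide. Compound 4 is therefore estimated at 200 nM in this assay, between 90 nM and 450 nM.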

Compound 4, dissociation constant: 119 nM
Estimate against measurement, compound 4: 1.7-fold (0.23 log units) above; measured number inside the range.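

In this assay, the change from phenyl to 4-chlorophenyl gives a 1.1-fold lower number from compound 3 to compound 4 (0.03 log units; within the scatter). Set beside the earlier step, the same change on the other core gives a result that cannot be told apart from this one: the same change on two cores in this assay, a 1.7-fold higher number (0.24 log units; within the scatter) from compound 1 to compound 2 and a 1.1-fold lower number (0.03 log units; within the scatter) from compound 3 to compound 4, 1.8-fold (0.27 log units) apart, within the scatter of two such steps. On these two cores, then, the change carries over in the sense that neither step leaves the usual scatter, but this does not show that chloro has no effect at all, as steps this small cannot be separated from repeat variation, and two cores say nothing firm about a third.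

The compounds shown leave open whether a different group at the same place on the ring, such as methoxy, nitrile or an amine, would shift the number beyond the scatter. Also open, on these data alone, is whether chloro would behave the same way on a core with a carboxylic acid in place of the bromine at the end of the chain.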